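Methoxy in place of hydrogen on the anilino ring

A few compounds are considered here, and "the series" means these few. Any claim that something is new, unique, unknown or untested is made for them only; others in the source may bear on it.

Measured so far:
Compound 1, `Cc1nc(SCC(=O)Nc2nc(-c3ccc(Cl)cc3)cs2)n(Nc2ccccc2)c1C`: 9940 nM
Compound 2, `Cc1ccc(Nn2c(SCC(=O)Nc3nc(-c4ccccc4)cs3)nc(C)c2C)cc1`: > 100000 nM

Both compounds were tested in a functional assay on MOLT-4 cells (Homo sapiens) for antiproliferative activity, read by sulforhodamine B assay, with a stated time of 48 h; on this read-out lower numbers stand for stronger inhibition of growth and higher numbers for weaker inhibition of growth. Among the compounds with values here, compound 1 gives 9940 nM, and this is the only actual number in the set. Compound 2 reaches only > 100000 nM, which is a limit of the assay and not a number. Within the data shown here, compound 2 differs from compound 1 in more than one place, so the two values show only that compound 1 gives a number and compound 2 does not.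

Compound 3, `COc1ccc(Nn2c(SCC(=O)Nc3nc(-c4ccc(Cl)cc4)cs3)nc(C)c2C)cc1`, has not yet been measured. It differs from compound 1 in a single place: methoxy in place of hydrogen on an aromatic carbon. The unmeasured compound keeps everything else of compound 1, including the chlorine on the other ring.

Among the measured compounds shown here, with no single-place step between measured compounds to lean on, the step from compound 1 to compound 3 is expected to be modest, at most a little beyond the scatter, and more likely toward weaker growth inhibition than stronger; in numbers, a 2.0-fold higher number from compound 1 to compound 3 (0.30 log units; within the scatter) is the expected step. Compound 3 is accordingly estimated at 20000 nM, with a range from 6000 nM to 100000 nM.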

Compound 3, concentration for total growth inhibition: > 100000 nM
Compound 3 ended at the assay's limit; the forecaster's own chance of this, stated with the estimate: 30%; at least 5.0-fold (0.69 log units) between middle value and limit.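

In this assay, the change from phenyl to 4-methoxyphenyl, with the rest of compound 1 kept, gives an at least 10-fold higher number from compound 1 to compound 3 (1.00 log units; beyond the scatter). Within the data shown here, this is the first comparison here in which only one part of the molecule changes, so the loss of measurable growth inhibition can be tied to this single change at this place on the anilino ring, which the earlier pair of compounds could not do. Compound 3 reads > 100000 nM, which is a limit of the assay and not a number, and the step is therefore only a lower bound on the real difference, because the read-out stops at a ceiling: the limit of > 100000 nM in this assay, at which 2 of the 3 values shown sit.

The compounds shown leave open whether this loss belongs to methoxy in particular or would follow from any group on this carbon, a question that a fluorine atom or a hydroxyl group at the same place would help to answer. They also leave open how far the result carries over to a different group, such as an amine, or to a core without the chlorine of compound 1.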